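The source may report more compounds than this note shows. Statements on the series, on what has been measured and on what is new or still open speak of the compounds shown alone.

Compound 2 `CC(C)c1ccc(-c2nc(SCc3cn(CC(=O)NC(=O)Nc4ccccn4)nn3)nc(Nc3ccccc3O)c2C#N)cc1` gives only a limit in a functional assay on MCF7 cells (Homo sapiens) for inhibition, read by MTT assay, with a stated time of 72 h (a lower number here means a stronger inhibitor, a higher number a weaker inhibitor), namely > 64000 nM. Compound 1 `Cc1ccccc1Nc1nc(SCc2cn(CC(=O)NC(=O)Nc3ccccn3)nn2)nc(-c2ccc(C(C)C)cc2)c1C#N` likewise gives only a limit, > 64000 nM. The step that the two limits leave unreadable from compound 1 to compound 2 therefore cannot be sized, since (the limit of > 64000 nM in this assay, at which 2 of the 2 values shown sit). Compound 3 `CC(C)c1ccc(Nc2nc(SCc3cn(CC(=O)NC(=O)Nc4ccccn4)nn3)nc(-c3ccc(C(C)C)cc3)c2C#N)cc1` differs from compound 2 by 4-isopropylphenyl in place of 2-hydroxyphenyl on a nitrogen on an aromatic ring. Within the data shown here, no measured step offers a readable size, and both neighbours sit at the limit, so no direction can be drawn from them. The expected step that the limit leaves unreadable from compound 2 to compound 3 is accordingly none beyond the scatter. Compound 3 is estimated at 100000 nM, with a range from 30000 nM to 400000 nM.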

Compound 3, half-maximal inhibitory concentration: 28600 nM
Estimate against measurement, compound 3: 3.5-fold (0.54 log units) above; measured number below the stated range.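

Among these compounds, at this position, on a nitrogen on an aromatic ring, 4-isopropylphenyl brings the first value that is more than a limit in this assay. In place of 2-hydroxyphenyl it gives an at least 2.2-fold lower number from compound 2 to compound 3 (0.34 log units; beyond the scatter), and in place of 2-methylphenyl it gives an at least 2.2-fold lower number from compound 1 to compound 3 (0.34 log units; beyond the scatter). Both steps are minimum sizes, because the other two compounds give only a limit: the limit of > 64000 nM in this assay, at which 2 of the 3 values shown sit.

From the compounds shown here alone, it remains open whether the isopropyl group itself or simply its place on the ring matters. A plain phenyl or a 4-carboxyphenyl group at this nitrogen could help separate the two.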